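Ethyl for Methyl on the Thiadiazole of an Oxime Ether

This account rests on a few compounds, and the source may have more. Where it says the series, first, only, none or still open, it means among the compounds named here.

The series is small. Going by the values given here, compound 2, `Cc1nnsc1CO/N=C/c1c(C)nn(C)c1Cl`, is the only member with a numeric result: in a functional assay on PANC-1 cells (Homo sapiens) for inhibition, read by MTT assay, with a stated time of 48 h (a higher number here means a weaker inhibitor, a lower number a stronger inhibitor), compound 2 gives 26600 nM. Compound 1, `CCc1nnsc1CO/N=C/c1c(C)nn(C)c1Oc1ccc(C)cc1`, carries an ethyl on the thiadiazole and an aryloxy group in place of the chlorine, so it differs from compound 2 in two places. In this assay compound 1 reaches only the limit of the assay, > 50000 nM, and no number is known for it. Against that backdrop, compound 2 stands as the single measured point, with one further result at the limit (the limit of > 50000 nM in this assay, at which 1 of the 2 values shown sits).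

Compound 3, `CCc1nnsc1CO/N=C/c1c(C)nn(C)c1Cl`, differs from compound 2 in one place: methyl in place of hydrogen on a saturated chain carbon bound to an aromatic carbon, which read one bond further out is methyl to ethyl on the thiadiazole. Among the compounds with values here, no measured pair shows this change alone, so it is unclear what size of step to expect. A single added carbon of this kind is expected to stay within the usual scatter, with perhaps a slight weakening given that compound 1, also carrying the ethyl, sits at the limit of the assay.

For compound 3 in this assay the expected value is therefore 32000 nM, within a range from 12000 nM to 80000 nM. The estimate means a step of a 1.2-fold higher number from compound 2 to compound 3 (0.08 log units; within the scatter), expected to lie within the scatter of the assay.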

Compound 3, half-maximal inhibitory concentration: > 50000 nM
Compound 3 ended at the assay's limit; the forecaster's own chance of this, stated with the estimate: 30%; middle value at least 1.5-fold (0.19 log units) from the limit.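

Methyl in place of hydrogen on a saturated chain carbon bound to an aromatic carbon, which also reads as methyl to ethyl, now has its first measured pair in this assay, with an at least 1.8-fold higher number from compound 2 to compound 3 (0.27 log units; that floor lies within the scatter). Going by these compounds alone, the floor of that step lies within the scatter, so the pair alone does not establish that the ethyl weakens the compound at this position, and compound 2 remains the only member with a number. Compound 3 keeps the chloro group and still gives a limit, so among the ethyl compounds a limit does not depend on the 4-methylphenoxy group, while the step between the two ethyl compounds cannot be read, since both results are limits: the limit of > 50000 nM in this assay, at which 2 of the 3 values shown sit.

Going by these compounds, the true size of the step from methyl to ethyl remains open, as does the effect of chloro against 4-methylphenoxy when the methyl is kept on the thiadiazole. Also open, on these data alone, is whether a longer chain such as propyl, or an amine or a carboxylic acid at this saturated chain carbon, would give a numeric result in this assay.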